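This account rests on a few compounds, and the source may have more. Where it says the series, first, only, none or still open, it means among the compounds named here.

Measured so far in an assay on isolated protein for inhibition of protein kinase C theta type (Homo sapiens), read by TR-FRET, with a stated time of 2 h; on this read-out higher numbers stand for weaker inhibition and lower numbers for stronger inhibition:

Compound 1, `CO[C@H]1CC[C@H](CNc2cc(NCc3cnccc3C(F)(F)F)ncc2C#N)CC1`: compound 1 gives 330 nM.
Compound 2, `CC1(C)[C@@H](O)C[C@H]1Nc1nc(NCc2cnccc2C(F)(F)F)ncc1C#N`: compound 2 gives 4 nM.

Compound 1 holds the highest of the two numbers in this assay. Among the measured compounds shown here, its nearest neighbour is compound 2, whose number lies far lower, well beyond the usual scatter of this read-out; the two compounds differ in more than one place, so their values show only that the pair spans a wide gap, not what any single change does.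

The step under consideration leads from compound 1 to compound 3, `CC1(C)[C@@H](Nc2cc(NCc3cnccc3C(F)(F)F)ncc2C#N)C[C@@H]1C(N)=O`. The change is 3-carbamoyl-2,2-dimethylcyclobutyl in place of (4-methoxycyclohexyl)methyl on a nitrogen on an aromatic ring. For the measured compounds named here, no measured pair isolates this change. Compound 2, the only other point, carries a dimethylcyclobutyl of related kind and gives 4 nM, but it also differs from compound 1 in its core, so the cyclobutyl cannot be credited with that gap on its own.

Compound 3 is nonetheless expected to land well below compound 1, with the step of an 8.3-fold lower number from compound 1 to compound 3 (0.92 log units; beyond the scatter) estimated to be beyond the scatter in the direction of stronger inhibition. The estimate for compound 3 in this assay is 40 nM, with a range from 8 nM to 200 nM.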

Compound 3, half-maximal inhibitory concentration: 1100 nM
Compound 3: middle estimate off by 28-fold (1.44 log units), on the low side, outside the stated range (above it).
By their numbers in this assay, from the lowest: compound 2; then compound 1; then compound 3.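

In this assay, among the compounds shown here, exchanging the one group that differs gives a 3.3-fold higher number from compound 1 to compound 3 (0.52 log units; beyond the scatter), a modest step toward weaker inhibition that lies beyond the scatter. For the compounds shown here, this is the first pair that isolates a change at this position on a shared core, showing that the read-out responds to the group held there and that this dimethylcyclobutyl, carrying its carbamoyl, does not bring stronger inhibition on this core. No measurement at hand bears on why the step runs in this direction.

The change swaps the ring, the carbamoyl and the methoxy group at once, so the compounds shown leave open which of these parts carries the step, and how the same 2,2-dimethylcyclobutyl would read with a carboxylic acid or an amine in place of the carbamoyl. Going by these compounds, compound 2 differs from compound 1 and from compound 3 in more than one place, so how its core and this group each contribute also remains open.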